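Chloro to trifluoromethyl in the clearance series

A few compounds are considered here, and "the series" means these few. Any claim that something is new, unique, unknown or untested is made for them only; others in the source may bear on it.

Of the compounds shown here, two have numbers so far in an ADME assay on microsomes from liver (Homo sapiens) for metabolic stability; a lower number here means slower removal, a higher number faster removal of the compound. Compound 1 (`O=C(O)CCNC(=O)c1ccc(C(Oc2ccc(-n3cc(C(F)(F)F)cn3)cc2)C2CCC2)cc1`) gives 26 mL/min/kg. Compound 2 (`CCCC(Oc1ccc(-n2cc(Cl)cn2)cc1)c1ccc(C(=O)NCCC(=O)O)cc1`) gives 10 mL/min/kg, the lower of the two numbers, and the gap between them lies beyond the usual scatter. Going by the values given here, these two compounds differ in more than one place, so no single-change step has been measured.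

Compound 3 (`CCCC(Oc1ccc(-n2cc(C(F)(F)F)cn2)cc1)c1ccc(C(=O)NCCC(=O)O)cc1`) is still unmeasured. It departs from compound 2 by one change: trifluoromethyl in place of chloro on an aromatic carbon. In words, trifluoromethyl stands in place of chloro on an aromatic carbon, turning 4-chloro-1H-pyrazol-1-yl into 4-(trifluoromethyl)-1H-pyrazol-1-yl. Compound 1 also carries 4-(trifluoromethyl)-1H-pyrazol-1-yl and gives 26 mL/min/kg, which points to a modest rise in this assay as the expected direction. Compound 1 differs from compound 3 elsewhere too, so it cannot fix the size of the step. The expected change, a 1.5-fold higher number from compound 2 to compound 3 (0.18 log units; within the scatter), is small and probably within the scatter. For compound 3 the estimated clearance is 15 mL/min/kg, with an expected range from 8 mL/min/kg to 28 mL/min/kg.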

Compound 3, clearance in the Homo sapiens assay: 16 mL/min/kg
Compound 3: middle estimate off by 1.1-fold (0.03 log units), on the low side, within the range that was stated.
By their numbers in the Homo sapiens assay, from the lowest: compounds 2, 3 and 1 (each within the scatter of the next, the first and the last beyond it).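

At this aromatic carbon of the five-membered aromatic ring, the Homo sapiens assay now has a single-change reading, a 1.6-fold higher number from compound 2 to compound 3 (0.20 log units; within the scatter), so 4-chloro-1H-pyrazol-1-yl and 4-(trifluoromethyl)-1H-pyrazol-1-yl are not separated on clearance. Compound 3 also links to compound 1 through one change, propyl in place of cyclobutyl, and in the Homo sapiens assay that step, a 1.6-fold lower number from compound 1 to compound 3 (0.21 log units; within the scatter), is likewise within the scatter, although compound 1 and compound 2, which differ at both places, lie beyond it. In a physicochemical assay for solubility, measured as kinetic solubility, at pH 6.5 (a lower number here means a less soluble compound, a higher number a more soluble compound), compound 2 gives 70000 nM and compound 3 gives 400000 nM. The swap of chloro for trifluoromethyl does separate the pair in the physicochemical assay: the measured solubility of compound 2, 70000 nM, and of compound 3, 400000 nM, a 5.7-fold higher number (0.76 log units; beyond the scatter)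

As far as these compounds go, the gap between compound 1 and compound 2 in the Homo sapiens assay is spread over two changes, each within the scatter alone, so the share of each stays open, as does whether the difference in the physicochemical assay holds with cyclobutyl in place of propyl. Also open, from the compounds shown here alone, is how a nitrile or a methyl at this ring carbon, or a longer chain in place of propyl, would read in either the Homo sapiens assay or the physicochemical assay.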